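This account rests on a few compounds, and the source may have more. Where it says the series, first, only, none or still open, it means among the compounds named here.

Measured so far:
compound 1 `O=c1cc(Cn2cc(C3CC3)nn2)c2ccc(O)cc2o1`: in a functional assay on A549 cells (Homo sapiens) for inhibition, read by MTT assay, with a stated time of 72 h (on this read-out higher numbers stand for weaker inhibition and lower numbers for stronger inhibition), compound 1 gives 91700 nM
compound 2 `O=c1cc(Cn2cc(CCCCO)nn2)c2ccc(O)cc2o1`: compound 2 gives > 100000 nM, which is a limit of this assay rather than a number
compound 3 `CC(C)(C)c1cn(Cc2cc(=O)oc3cc(O)ccc23)nn1`: compound 3 gives 67600 nM

Compound 1 stands highest of the two numbers given; its nearest neighbour is compound 3, with a 1.4-fold lower number from compound 1 to compound 3 (0.13 log units; within the scatter). The value of compound 2 sits at the limit of > 100000 nM in this assay, at which 1 of the 3 values shown sits, so that an at least 1.0-fold higher number from compound 1 to compound 2 (0.03 log units; that floor lies within the scatter) rests on a floor only. Between the other two, an at least 1.4-fold lower number from compound 2 to compound 3 (0.17 log units; that floor lies within the scatter).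

Compound 4 `CCCCCCc1cn(Cc2cc(=O)oc3cc(O)ccc23)nn1` differs from compound 1 by hexyl in place of cyclopropyl on an aromatic carbon. Going by the values given here, the steps that bear on it are the two changes made at the same aromatic carbon: the move to tert-butyl, a 1.4-fold lower number from compound 1 to compound 3 (0.13 log units; within the scatter), and the move to the 4-hydroxybutyl chain, an at least 1.0-fold higher number from compound 1 to compound 2 (0.03 log units; that floor lies within the scatter). Neither left the scatter, and all three measured compounds sit close together in this assay. A saturated hexyl chain in this position is therefore expected to give no step beyond the scatter, a 1.4-fold lower number from compound 1 to compound 4 (0.15 log units; within the scatter). Compound 4 is estimated at 65000 nM, with a range from 20000 nM to 150000 nM.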

Compound 4, half-maximal inhibitory concentration: 66200 nM
Beside the measured number, compound 4's estimate is 1.0-fold (0.01 log units) below it; the range from low to high includes it.
By their numbers in this assay, from the lowest: compounds 4, 3 and 1 (each within the scatter of the next). At a limit, above all of these: compound 2.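

In this assay, the open hexyl chain takes the place of the cyclopropyl ring on this aromatic carbon without a step that leaves the scatter (a 1.4-fold lower number from compound 1 to compound 4 (0.14 log units; within the scatter)). The same holds against tert-butyl (a 1.0-fold lower number from compound 3 to compound 4 (0.01 log units; within the scatter)), so cyclopropyl, tert-butyl and hexyl are not told apart at this position in this assay. With ethyl in place of hydroxy at the chain end, the reading (an at least 1.5-fold lower number from compound 2 to compound 4 (0.17 log units; that floor lies within the scatter)) is only a floor, since compound 2 stands at a limit and not at a number: the limit of > 100000 nM in this assay, at which 1 of the 4 values shown sits.

On these data alone, whether any group on this carbon can carry the number beyond the scatter remains open. The compounds shown say nothing about an amine, a carboxylic acid, a phenyl ring or a chain longer than hexyl here.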